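The source may hold more compounds than are shown below. What is called first, only, known or untested is meant among the compounds shown, and "the series" means these compounds.

Values in an ADME assay on HEK293 cells (Homo sapiens) for cytotoxicity, with a stated time of 6 h (a higher number here means that more compound is tolerated, a lower number that less compound is tolerated), for the series so far:
- compound 1 `CCCCNc1nc(N)nc2cc(OC)ccc12` gives > 18000 nM (a limit)
- compound 2 `CCCCNc1nc(N)nc2ccc(CO)cc12` gives > 18000 nM (a limit)
- compound 3 `CCCCNc1nc(N)nc2cccc(Cl)c12` gives 100 nM (a measured number)

Within the data shown here, compound 3 (100 nM) holds the only actual number in the set. Compound 1 and compound 2 are covered by the limit of > 18000 nM in this assay, at which 2 of the 3 values shown sit, and give no number.

Compound 4 `CCCCNc1nc(N)nc2cccc(OCc3ccccc3)c12` is still to be measured in this assay and differs from compound 3 as follows: benzyloxy in place of chloro on an aromatic carbon. Among the measured compounds shown here, no measured step covers this change, so the expectation has no direct support and its range stays wide.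

For the measured compounds named here, compound 3 (100 nM) is the only compound here with an actual number, and compound 4 carries its new group on the same aromatic carbon. Going by the values given here, the one number therefore remains the anchor, with room upward only. A move towards more compound being tolerated is expected, and a 10-fold higher number from compound 3 to compound 4 (1.00 log units; beyond the scatter) is estimated to lie beyond the scatter. A result reported only as a limit would fit this expectation too. Compound 4 is expected at 1000 nM with 60 nM to 18000 nM as the estimated range.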

Compound 4, half-maximal cytotoxic concentration: 10000 nM
Compound 4: middle estimate off by 10-fold (1.00 log units), on the low side; low and high end bracket the measured number.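

In this assay, the aromatic carbon that carries chloro in compound 3 does not by itself tie the series to a low number: benzyloxy in place of chloro there gives a 100-fold higher number from compound 3 to compound 4 (2.00 log units; beyond the scatter). Among these compounds, this is the first measured step, and it shows that, with the rest of the structure unchanged, the group on this carbon alone can move the read-out far beyond the scatter. Compound 4 also gives an actual number, so the step can be read in full, whereas compound 1 and compound 2 offer only limits and no number to compare with: the limit of > 18000 nM in this assay, at which 2 of the 4 values shown sit.

A single step cannot show whether the change in the read-out follows from chloro leaving or from benzyloxy entering, or which part of benzyloxy, the oxygen or the aromatic ring, matters. The compounds shown also leave open how a hydroxyl, an amine or a plain phenyl on this same aromatic carbon would sit relative to compound 3 and compound 4.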